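Trifluoromethyl on the anilino ring across two cores

The source may report more compounds than this note shows. Statements on the series, on what has been measured and on what is new or still open speak of the compounds shown alone.

Compound 1 `COc1cc(Nc2nc(C(=N)Nc3ccccc3)cc3c(-c4ccccc4)n[nH]c23)cc(OC)c1OC` in a functional assay on MDA-MB-231 cells (Homo sapiens) for cytotoxicity, read by MTT assay, with a stated time of 72 h (on this read-out higher numbers stand for weaker inhibition and lower numbers for stronger inhibition), gives 4500 nM. Compound 2 `COc1cc(Nc2nc(C(=N)Nc3cccc(C(F)(F)F)c3)cc3c(-c4ccccc4)n[nH]c23)cc(OC)c1OC` in this assay gives 7600 nM. The step of a 1.7-fold higher number from compound 1 to compound 2 (0.23 log units; within the scatter) belongs to trifluoromethyl in place of hydrogen on an aromatic carbon. Compound 3 `Cn1cc2cc(C(=N)Nc3ccccc3)ncc2n1` carries a different core; the difference between the two cores is not broken down here. In this assay compound 3 reaches only the limit > 50000 nM, which is a limit of the assay and not a number, as noted in the limit of > 50000 nM in this assay, at which 1 of the 3 values shown sits. Within the data shown here, compound 4 `Cn1cc2cc(C(=N)Nc3cccc(C(F)(F)F)c3)ncc2n1` has not been measured; it differs from compound 3 by trifluoromethyl in place of hydrogen on an aromatic carbon, the same change as the one from compound 1 to compound 2. The step expected is a step that the limit leaves unreadable from compound 3 to compound 4, small like a 1.7-fold higher number from compound 1 to compound 2 (0.23 log units; within the scatter), which rests on that measured pair alone. Since compound 3 sits at a limit, compound 4 is expected to give about 90000 nM, most likely again only a limit, within 40000 nM to 250000 nM.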

Compound 4, half-maximal inhibitory concentration: > 50000 nM
Compound 4 gave a limit, no number; the forecaster's own chance of this, stated with the estimate: 85%; the middle value does not contradict the limit.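

In this assay, compound 3 and compound 4 both stand at a limit, so no step between them can be read: the limit of > 50000 nM in this assay, at which 2 of the 4 values shown sit.

Going by these compounds, whether trifluoromethyl in place of hydrogen on an aromatic carbon changes the read-out on the core of compound 3 remains open.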